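This account rests on a few compounds, and the source may have more. Where it says the series, first, only, none or still open, it means among the compounds named here.

Measured so far:
- Compound 1, `Cc1ccc(S(=O)(=O)N[C@H]2CC[C@@H](F)[C@@H]2C/C=C\CCCC(=O)O)cc1`: in a functional assay on a cell-free system (plasma) for inhibition of thromboxane A2 receptor (Homo sapiens), read by turbidimetry (on this read-out higher numbers stand for weaker inhibition and lower numbers for stronger inhibition), compound 1 gives 260 nM
- Compound 2, `O=C(O)COCCCC[C@H]1[C@H](F)CC[C@@H]1NS(=O)(=O)c1ccc(F)cc1F`: in this assay compound 2 gives 1800 nM

For the measured compounds named here, of these two numbers, the one for compound 2 is the higher, so on this read-out compound 2 is the weaker inhibitor of the pair; the two values are far enough apart that the gap is beyond the scatter of repeated measurements. The two compounds differ in more than one place, so nothing is known about how much of that gap belongs to any single change.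

Compound 3, `O=C(O)COCCCC[C@H]1[C@H](F)CC[C@@H]1NS(=O)(=O)c1ccc(F)cc1`, has not yet been measured. It differs from compound 2 by a single change: hydrogen in place of fluoro on an aromatic carbon. This places hydrogen in place of fluoro on an aromatic carbon ortho to a large group, leaving the other fluoro in place.

Going by the values given here, since no step between measured compounds isolates this change, the expectation is modest. Compound 3 is expected to give 900 nM, with a range from 300 nM to 2500 nM. The expected step of a 2.0-fold lower number from compound 2 to compound 3 (0.30 log units; within the scatter) points toward somewhat stronger inhibition, but may well fall within the scatter.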

Compound 3, half-maximal inhibitory concentration: 1800 nM
Compound 3: the middle estimate sits 2.0-fold (0.30 log units) below what was measured; the range from low to high includes it.
By their numbers in this assay, from the lowest: compound 1; then compounds 2 and 3 (each within the scatter of the next).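

Taking away the fluoro ortho to a large group, which turns 2,4-difluorophenyl into 4-fluorophenyl, gives no change at the digits printed from compound 2 to compound 3 (within the scatter) in this assay. For the compounds shown here, this is the first comparison in which only one place differs, so a single change can now be read on its own. Within this pair, the fluoro at this position can be replaced by hydrogen with no change beyond the scatter, although nothing available here speaks to the reason for this result.

The compounds shown leave open whether the same would hold with a different group at this position, such as a chloro or a methoxy group. They also leave open what would happen if the remaining fluoro were replaced by hydrogen, and whether this pair's outcome would carry over to other chains on the shared core.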